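The source may report more compounds than this note shows. Statements on the series, on what has been measured and on what is new or still open speak of the compounds shown alone.

Measured compounds:
compound 1 `COc1ccc(-c2ccc(OCc3cc(C(=O)NS(=O)(=O)c4cccs4)oc3C)cc2)cc1` — 3.6 nM
compound 2 `COc1ccc(-c2ccc(OCc3cc(C(=O)NS(=O)(=O)c4ccc(CN)cc4)oc3C)cc2)cc1` — 100 nM
compound 3 `Cc1oc(C(=O)O)cc1COc1ccc(-c2ccc(CO)cc2)cc1` — 3000 nM

In an assay on cells for displacement of a labelled ligand from prostaglandin E2 receptor EP4 subtype (Homo sapiens), read by scintillation counting (on this read-out higher numbers stand for weaker inhibition and lower numbers for stronger inhibition), compound 2 holds the second highest of the three numbers. Its nearest neighbour is compound 1, reached by the step of a 28-fold higher number from compound 1 to compound 2 (1.44 log units; beyond the scatter) run backwards, and compound 3, which carries a free acid and a hydroxymethyl group where the others carry a biaryl ether and an acylsulfonamide, gives a still higher number. Compound 4 `CCCS(=O)(=O)NC(=O)c1cc(COc2ccc(-c3ccc(OC)cc3)cc2)c(C)o1` has not yet been measured. It differs from compound 2 in one place: propyl in place of 4-(aminomethyl)phenyl on a sulfonyl sulfur. Within the data shown here, the only measured step that touches the same position is a 28-fold higher number from compound 1 to compound 2 (1.44 log units; beyond the scatter), which shows that the group on the sulfonyl sulfur can move this read-out by a large amount. That step, however, exchanges one ring for another, whereas here a ring with a donor and an acceptor is replaced by a short chain with neither, so its size cannot be transferred directly. Given that compound 1 shows a much lower number with a different sulfonyl substituent, compound 4 is expected to give a lower number than compound 2, by about a 5.0-fold lower number from compound 2 to compound 4 (0.70 log units; beyond the scatter). The estimate for compound 4 in this assay is 20 nM, within a range from 5 nM to 80 nM.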

Compound 4, inhibition constant in the prostaglandin E2 receptor EP4 subtype assay: 5 nM
Beside the measured number, compound 4's estimate is 4.0-fold (0.60 log units) above it; low and high end bracket the measured number.
By their numbers in the prostaglandin E2 receptor EP4 subtype assay, from the lowest: compounds 1 and 4 (each within the scatter of the next); then compound 2; then compound 3.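

In the prostaglandin E2 receptor EP4 subtype assay, the sulfonyl sulfur turns out not to need a ring for a low number: propyl in place of 4-(aminomethyl)phenyl gives a 20-fold lower number from compound 2 to compound 4 (1.30 log units; beyond the scatter), while propyl in place of thiophen-2-yl gives a 1.4-fold higher number from compound 1 to compound 4 (0.14 log units; within the scatter), so these two groups cannot be told apart on this read-out. In a physicochemical assay for solubility, in phosphate buffer, with a stated time of 24 h, at pH 7.4 (a higher number here means a more soluble compound, a lower number a less soluble compound), the change from 4-(aminomethyl)phenyl to propyl also goes with higher solubility: the measured solubility of compound 2, < 0.6 ug/mL, and of compound 4, 7 ug/mL, an at least 11-fold higher number (1.06 log units; beyond the scatter) In the physicochemical assay compound 2 gives < 0.6 ug/mL, which is a limit of the assay and not a number, so the size of this step is only a bound. In the physicochemical assay compound 4 gives 7 ug/mL.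

Which part of the 4-(aminomethyl)phenyl group goes with the higher binding number of compound 2 stays open: the compounds shown hold no plain phenyl on the sulfonyl sulfur that would separate the ring from the amine. They also leave open how a longer chain such as butyl, or a propyl chain ending in an amine or a carboxylic acid, would read in either assay.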